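The compounds below may be only part of what the source reports. "The series", "measured", "known", "first", "only" and "open" are said of these compounds alone.

Working notes on the series. Compound 1 `O=C1/C(=C/c2cccnc2)CN(S(=O)(=O)c2ccc(F)cc2)C/C1=C\c1ccccc1F` carries a fluoro on the sulfonyl-bearing ring, and in an ADME assay on L02 cells (Homo sapiens) for cytotoxicity, read by MTT assay, with a stated time of 24 h (on this read-out lower numbers stand for stronger inhibition and higher numbers for weaker inhibition), compound 1 gives 15600 nM. Compound 2 `O=C1/C(=C/c2cccnc2)CN(S(=O)(=O)c2ccc(Cl)cc2)C/C1=C\c1ccccc1F` differs from compound 1 in one place, (chloro in place of fluoro on an aromatic carbon). In this assay compound 2 returns only a limit of the assay, > 20000 nM. The measured step is an at least 1.2-fold higher number from compound 1 to compound 2 (0.10 log units; that floor lies within the scatter); its true size is not resolved, since the value of compound 2 sits at the limit of > 20000 nM in this assay, at which 1 of the 3 values shown sits.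

Compound 3 `O=C1/C(=C/c2ccncc2)CN(S(=O)(=O)c2ccc(F)cc2)C/C1=C\c1ccccc1C(F)(F)F` is built on a different core; the difference between the core of compound 3 and the core of compound 1 is not broken down here. In this assay compound 3 gives 12900 nM, a value that lies within the scatter of the value of compound 1, so no order between the two is claimed.

Compound 4 `O=C1/C(=C/c2ccncc2)CN(S(=O)(=O)c2ccc(Cl)cc2)C/C1=C\c1ccccc1C(F)(F)F` has not yet been measured in this assay. It differs from compound 3 by chloro in place of fluoro on an aromatic carbon, the same change that turns compound 1 into compound 2, made here on the core of compound 3. Among the measured compounds shown here, only one measured instance of this change exists, and it ends at a limit, so the expectation for compound 4 is loose. The step from compound 3 to compound 4 is expected to be a 1.6-fold higher number from compound 3 to compound 4 (0.19 log units; within the scatter), resting on the earlier step of an at least 1.2-fold higher number from compound 1 to compound 2 (0.10 log units; that floor lies within the scatter). Compound 4 is accordingly expected to give about 20000 nM, with a plausible range from 10000 nM to 40000 nM, and a fair chance that the assay again reports only a limit.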

Compound 4, half-maximal inhibitory concentration: 14900 nM
Compound 4: the middle estimate sits 1.3-fold (0.13 log units) above what was measured; low and high end bracket the measured number.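

In this assay, going from (4-fluorophenyl)sulfonyl to (4-chlorophenyl)sulfonyl on the second core gives a 1.2-fold higher number from compound 3 to compound 4 (0.06 log units; within the scatter), so in this pair the change produces no step beyond the scatter. Set beside the earlier instance, the new step compares as follows: the same change on two cores in this assay, an at least 1.2-fold higher number (0.10 log units; that floor lies within the scatter) from compound 1 to compound 2 and a 1.2-fold higher number (0.06 log units; within the scatter) from compound 3 to compound 4; the limit leaves it open whether they differ. Compound 2 returns only a limit of the assay, > 20000 nM, so the series shows that the change can be made on the second core without a step beyond the scatter, but it does not show that the change has the same size on both cores, or that its size depends on the core.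

The compounds shown carry only fluoro or chloro at this place, which leaves open what a bromo group, a methoxy group, an amine or a carboxylic acid would do there in this assay. Also open, going by these compounds, is how the change behaves on any further core, as the two pairs, one of them ending at a limit, are all that bears on it so far.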